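The compounds below may be only part of what the source reports. "The series", "measured", "known", "first", "only" and "open" are said of these compounds alone.

In an ADME assay on CCRF-CEM cells (Homo sapiens) for cytotoxicity, with a stated time of 4 days (on this read-out higher numbers stand for lower toxicity in this test and lower numbers for higher toxicity in this test), compound 1 `COC(=O)n1c(=O)c(C)cn([C@@H]2O[C@H](CO[Si](C)(C)C(C)(C)C)[C@@]3(OS(=O)(=O)C=C3N)[C@H]2O[Si](C)(C)C(C)(C)C)c1=O` gives > 100000 nM, which is a limit of the assay and not a number. Among the compounds with values here, compound 2 `CNC(=O)CCCC(=O)n1c(=O)c(C)cn([C@@H]2O[C@H](CO[Si](C)(C)C(C)(C)C)[C@@]3(OS(=O)(=O)C=C3N)[C@H]2O[Si](C)(C)C(C)(C)C)c1=O` gives 9100 nM, the only true number available so far. Within the data shown here, the one measured step, an at least 10-fold lower number from compound 1 to compound 2 (1.04 log units; beyond the scatter), is large and beyond the scatter, and it places 3-(methylcarbamoyl)propyl where methoxy stood on a carbonyl carbon. Compound 3 `Cc1cn([C@@H]2O[C@H](CO[Si](C)(C)C(C)(C)C)[C@@]3(OS(=O)(=O)C=C3N)[C@H]2O[Si](C)(C)C(C)(C)C)c(=O)n(C(=O)CCCC(=O)OCc2ccccc2)c1=O` differs from compound 2 only at the end of that group: benzyloxy in place of methylamino on a carbonyl carbon. The measured step replaced the whole group, so it offers only a loose guide to this smaller change. In this assay, the expected step of a 1.1-fold lower number from compound 2 to compound 3 (0.06 log units; within the scatter) is small, with no firm direction and probably within the scatter. For compound 3, the estimated value is 8000 nM, with an expected range from 2500 nM to 30000 nM.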

Compound 3, half-maximal cytotoxic concentration: 9200 nM
The estimate for compound 3 lay 1.2-fold (0.06 log units) below the measured number; the measured number falls inside the stated range.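

In this assay, benzyloxy in place of methylamino on a carbonyl carbon gives a 1.0-fold higher number from compound 2 to compound 3 (0.00 log units; within the scatter). This end of the chain therefore accepts a larger group carrying an aromatic ring, and the loss of a hydrogen-bond donor, with no difference that this test can separate from scatter. Compound 1, with methoxy on the carbonyl carbon and no such chain, remains the only compound shown at a limit of the assay: the limit of > 100000 nM in this assay, at which 1 of the 3 values shown sits.

On these data alone, whether the chain end matters at all in this test remains open, since a free carboxylic acid or a primary amine at that end could still behave differently from methylamino and benzyloxy. The compounds shown also leave open how a shorter or a longer chain would read, with either end group kept in place.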